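This account rests on a few compounds, and the source may have more. Where it says the series, first, only, none or still open, it means among the compounds named here.

In an ADME assay on MT4 cells (Homo sapiens) for cytotoxicity, read by MTT assay, with a stated time of 5 days (a lower number here means that less compound is tolerated, a higher number that more compound is tolerated), three compounds with a shared core have been measured. Compound 1 `Cc1cc(C)cc(S(=O)(=O)n2c(SCC(=O)Nc3ccccc3C)nc3ccccc32)c1` gives 6150 nM, compound 2 `COC(=O)c1ccc(NC(=O)CSc2nc3ccccc3n2S(=O)(=O)c2cc(C)cc(C)c2)cc1` gives 10000 nM, and compound 3 `Cc1cc(C)cc(S(=O)(=O)n2c(SCC(=O)Nc3ccc(S(N)(=O)=O)cc3)nc3ccccc32)c1` gives 30900 nM, the highest of the three. Compound 4 `Cc1cc(C)cc(S(=O)(=O)n2c(SCC(=O)Nc3ccc(S(N)(=O)=O)cc3Cl)nc3ccccc32)c1` differs from compound 3 by a single change, chloro in place of hydrogen on an aromatic carbon, ortho to a large group and meta to a sulfamoyl group.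

Going by the values given here, no measured step adds a chloro. The nearest evidence comes from changes on the same aromatic ring, which gave a 5.0-fold higher number from compound 1 to compound 3 (0.70 log units; beyond the scatter) and a 3.1-fold higher number from compound 2 to compound 3 (0.49 log units; beyond the scatter), both modest, whereas the remaining comparison gave a 1.6-fold higher number from compound 1 to compound 2 (0.21 log units; within the scatter), within the scatter. Both modest steps lead up to compound 3, so a small change away from it is expected to leave the number unchanged or somewhat lower in this assay. The expected step is a 1.4-fold lower number from compound 3 to compound 4 (0.15 log units; within the scatter), a slight lowering that may stay within the scatter. Compound 4 is estimated at 22000 nM, with an expected range from 9000 nM to 50000 nM.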

Compound 4, half-maximal cytotoxic concentration: 25600 nM
For compound 4 the middle estimate is 1.2-fold (0.07 log units) below the measured one; measured number inside the range.
By their numbers in this assay, from the lowest: compounds 1 and 2 (each within the scatter of the next); then compounds 4 and 3 (each within the scatter of the next).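

In this assay, the place ortho to a large group and meta to a sulfamoyl group accepts a chloro in place of hydrogen with the number staying within the scatter, as a 1.2-fold lower number from compound 3 to compound 4 (0.08 log units; within the scatter) shows. The 2-chloro-4-sulfamoylphenyl group also keeps the separation from the other two compounds, with a 2.6-fold higher number from compound 2 to compound 4 (0.41 log units; beyond the scatter) and a 4.2-fold higher number from compound 1 to compound 4 (0.62 log units; beyond the scatter), both modest and beyond the scatter. The data shown offer no measurement that accounts for these results.

The compounds shown contain only one substituent at this place, so it remains open whether an amine, a carboxylic acid or a longer chain there would also stay within the scatter of compound 3. On these data alone, it also remains open whether a chloro would give the same result on the 4-(methoxycarbonyl)phenyl ring of compound 2.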